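Removing a phenol hydroxy from a naphthol-type compound

The compounds below may be only part of what the source reports. "The series", "measured", "known", "first", "only" and "open" are said of these compounds alone.

Compound 1 `Oc1cccc(-c2ccc3c(-c4cncnc4)c(O)ccc3c2)c1` carries a hydroxy on the outer phenyl ring; in an assay for binding affinity to 17-beta-hydroxysteroid dehydrogenase type 1 (Homo sapiens), read by scintillation counting, with a stated time of 10 min, tested at 1 uM (on this read-out higher numbers stand for more inhibition at the one concentration tested (going by the name of the read-out) and lower numbers for less inhibition), compound 1 gives 41%, the lower of the two numbers in hand. Compound 2 `Cn1cc(-c2c(O)ccc3cc(-c4cccc(O)c4)ccc23)cn1` differs only in the heteroaryl group and gives 71%, so that a number 30 percentage points higher from compound 1 to compound 2 (beyond the scatter) sets compound 1 at the bottom. Compound 3 `Oc1ccc2cc(-c3ccccc3)ccc2c1-c1cncnc1` is compound 1 with hydrogen in place of hydroxy on an aromatic carbon. Among the measured compounds shown here, no measured step bears on this change: the one step in hand concerns the heteroaryl group, not the outer phenyl ring, and the data hold no pair differing by a hydroxy. The expectation for compound 3 therefore rests on compound 1 alone, and its number is estimated at 25% within 5% to 50%. The step this estimate means, a number 16 percentage points lower from compound 1 to compound 3 (beyond the scatter), is expected as a modest fall, but it could lie within the scatter.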

Compound 3, a percentage reported as inhibition, at one concentration (the size of the read-out at that concentration, not a potency): 22%
The estimate for compound 3 lay 3 percentage points above the measured number; measured number inside the range.
By their numbers in this assay, from the lowest: compound 3; then compound 1; then compound 2.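

In this assay, the change from 3-hydroxyphenyl to phenyl gives a number 19 percentage points lower from compound 1 to compound 3 (beyond the scatter), so the outer ring now has a measured step of its own, whereas the earlier step concerned only the heteroaryl group. With pyrimidin-5-yl on the core, the hydroxy at this place therefore counts towards the inhibition seen at the one concentration tested. Nothing in hand explains why the number falls when the hydroxy leaves.

Whether the same fall follows with 1-methyl-1H-pyrazol-4-yl as the heteroaryl group remains open, as the compounds shown include no phenyl partner for compound 2. On these data alone, it is also open how another group at this place would compare with hydroxy and hydrogen, for example an amine or a carboxylic acid.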